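This account rests on a few compounds, and the source may have more. Where it says the series, first, only, none or still open, it means among the compounds named here.

Measured compounds:
- compound 1, `Cc1cccc(CN(C)C(=O)c2cc3c(Cc4ccccc4)n[nH]c3cc2O)c1`: "not determined" (no result reported)
- compound 2, `CN(Cc1ccccc1)C(=O)c1cc2c(Cc3cccc(F)c3)n[nH]c2cc1O`: 1700 nM

In a functional assay on A2780 cells (Homo sapiens) for antiproliferative activity, read by resazurin assay, with a stated time of 72 h (a higher number here means a weaker inhibitor, a lower number a stronger inhibitor), compound 2 gives 1700 nM. Within the data shown here, it is the only compound of the series with a number in this assay; compound 1 was run without a result being reported, so no step between measured compounds can be read off, and compound 2 stands alone as the sole reference point.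

Compound 3 `CN(Cc1ccccc1)C(=O)c1cc2c(CCc3ccccc3)n[nH]c2cc1O` has not been measured in this assay. It differs from compound 2 in one place: benzyl in place of 3-fluorophenyl on a saturated chain carbon bound to an aromatic carbon. Two groups of equal heavy-atom count, each one six-membered aromatic ring of carbon only, with no change in hydrogen-bond donors or acceptors and no change in charge, are swapped on a saturated chain carbon bound to an aromatic carbon.

Among the measured compounds shown here, with no measured step available, the size of the change is expected to stay within the usual scatter of this assay, with no direction beyond it. The step from compound 2 to compound 3 is expected to be a 1.2-fold higher number from compound 2 to compound 3 (0.07 log units; within the scatter). Compound 3 is estimated at 2000 nM in this assay, within a range of 800 nM to 5000 nM.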

Compound 3, half-maximal inhibitory concentration: 4600 nM
For compound 3 the middle estimate is 2.3-fold (0.36 log units) below the measured one; low and high end bracket the measured number.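

In this assay, among these compounds, the exchange of 3-fluorophenyl for benzyl on a saturated chain carbon bound to an aromatic carbon gives a 2.7-fold higher number from compound 2 to compound 3 (0.43 log units; beyond the scatter), the first readable step. It shows that this position responds to the exchange, modestly but beyond the scatter, although the heavy-atom count, the six-membered aromatic ring of carbon only, the absence of hydrogen-bond donors and acceptors, and the absence of net charge all stay the same. Cut one bond further out, the same difference reads 3-fluorobenzyl to phenethyl, so this single step combines the loss of fluorine with the extra chain carbon, and no measurement shown here accounts for the step or separates these two parts.

The compounds shown leave open whether a 3-fluorophenethyl group would separate the contribution of the fluorine from that of the chain. They also leave open how the number would respond to a longer chain such as 3-phenylpropyl, or to a basic amine such as dimethylaminomethyl or a carboxylic acid at the end of the chain.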